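The source may hold more compounds than are shown below. What is called first, only, known or untested is meant among the compounds shown, and "the series" means these compounds.

Compound 1 `O=C(/N=C(/NC(=O)c1ccno1)[Se]Cc1ccccc1)c1ccno1` was tested in a functional assay on K562 cells (Homo sapiens) for cytotoxicity, read by MTT assay, with a stated time of 72 h (a higher number here means a weaker inhibitor of growth, a lower number a stronger inhibitor of growth), where compound 1 gives 57300 nM. Compound 2 `C[Se]/C(=N\C(=O)c1ccno1)NC(=O)c1ccno1` shares its core and differs from it only by hydrogen in place of phenyl on a saturated chain carbon bound to a selenium atom; in this assay compound 2 gives 45600 nM. The step of a 1.3-fold lower number from compound 1 to compound 2 (0.10 log units; within the scatter) is small, so the two values cannot be told apart on this evidence.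

Compound 3 `O=C(/N=C(/NC(=O)c1csc([N+](=O)[O-])c1)[Se]Cc1ccccc1)c1csc([N+](=O)[O-])c1` carries a different core from compound 1, and the difference between the two cores is not broken down here. In this assay compound 3 gives 55800 nM, a value that sits close to that of compound 1 and also close to that of compound 2, with all three within the scatter of one another.

Compound 4 `C[Se]/C(=N\C(=O)c1csc([N+](=O)[O-])c1)NC(=O)c1csc([N+](=O)[O-])c1` is the counterpart of compound 3 in the same sense that compound 2 is the counterpart of compound 1: it differs from compound 3 by hydrogen in place of phenyl on a saturated chain carbon bound to a selenium atom, which is the same change as that from compound 1 to compound 2, made at the same place and on the core of compound 3. Among the measured compounds shown here, since the only measured instance of this change, a 1.3-fold lower number from compound 1 to compound 2 (0.10 log units; within the scatter), lies within the scatter, compound 4 is expected to show a step of about a 1.3-fold lower number from compound 3 to compound 4 (0.10 log units; within the scatter) from compound 3, and that expectation rests on a 1.3-fold lower number from compound 1 to compound 2 (0.10 log units; within the scatter) alone. On that basis compound 4 is estimated to give about 44000 nM in this assay, most likely between 25000 nM and 80000 nM.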

Compound 4, concentration for total growth inhibition: > 100000 nM
Compound 4 ended at the assay's limit (the forecaster's own chance of this, stated with the estimate: 5%); at least 2.2-fold (0.35 log units) between middle value and limit.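

In this assay compound 4 gives > 100000 nM, which is a limit of the assay and not a number. From the compounds shown here alone, replacing benzyl with methyl on the core of compound 3 can therefore be read only as a floor, an at least 1.7-fold higher number from compound 3 to compound 4 (0.25 log units; that floor lies within the scatter), and the true size of this step remains unknown. The series thus offers no firm sign that this change carries over from one core to another, and equally none that its effect depends on the core, since the two measured instances cannot be separated: the same change on two cores in this assay, a 1.3-fold lower number (0.10 log units; within the scatter) from compound 1 to compound 2 and an at least 1.7-fold higher number (0.25 log units; that floor lies within the scatter) from compound 3 to compound 4; the limit leaves it open whether they differ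

The compounds shown leave open how large the step on the core of compound 3 really is, and whether the change would behave in the same way on any further core, as only two matched pairs are available. They also leave open what a longer chain, such as propyl, or a chain ending in an amine or a carboxylic acid would give in place of benzyl or methyl on either core.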